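Halogenated phenyl in place of trifluoromethylphenyl: cytotoxicity notes

The source may hold more compounds than are shown below. What is called first, only, known or untested is meant among the compounds shown, and "the series" means these compounds.

Compound 1 `COc1ccc(-c2cc(=O)c3c(O)cc(OCCCCN4CCN(C)CC4)c(OC)c3o2)cc1`: 4200 nM
Compound 2 `COc1c(OCCCCN2CCN(C)CC2)cc(O)c2c(=O)cc(-c3ccc(C(F)(F)F)cc3)oc12`: 2400 nM

In a functional assay on HepG2 cells (Homo sapiens) for cytotoxicity, read by MTT assay, with a stated time of 72 h (a higher number here means a weaker inhibitor, a lower number a stronger inhibitor), compound 2 gives the lower of the two numbers, though the step of a 1.8-fold lower number from compound 1 to compound 2 (0.24 log units; within the scatter) is within the scatter. Compound 3 `COc1c(OCCCCN2CCN(C)CC2)cc(O)c2c(=O)cc(-c3ccc(F)cc3Br)oc12` differs from compound 2 by 2-bromo-4-fluorophenyl in place of 4-(trifluoromethyl)phenyl on an aromatic carbon. Among the measured compounds shown here, the single measured step bears on it only loosely: it also exchanged the group on an aromatic carbon and moved little. No shift beyond the scatter is therefore expected, and compound 3 is estimated at 2500 nM, within 1000 nM to 6000 nM, meaning an expected step of a 1.0-fold higher number from compound 2 to compound 3 (0.02 log units; within the scatter).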

Compound 3, half-maximal inhibitory concentration: 2130 nM
For compound 3 the middle estimate is 1.2-fold (0.07 log units) above the measured one; the measured number falls inside the stated range.
By their numbers in this assay, from the lowest: compounds 3, 2 and 1 (each within the scatter of the next).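

On the aromatic carbon next to the ring oxygen, 2-bromo-4-fluorophenyl gives a 1.1-fold lower number from compound 2 to compound 3 (0.05 log units; within the scatter) in this assay and a 2.0-fold lower number from compound 1 to compound 3 (0.29 log units; within the scatter) on the same read-out. Both steps stay within the scatter, so this ring, carrying bromine and fluorine together, cannot be told apart from 4-(trifluoromethyl)phenyl or 4-methoxyphenyl at this position. No measurement at hand accounts for this flat response.

Still open, going by these compounds, is whether an amine or a carboxylic acid on this phenyl ring would move the number in this assay beyond the scatter.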